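Working notes: from compound 3 to compound 4

A few compounds are considered here, and "the series" means these few. Any claim that something is new, unique, unknown or untested is made for them only; others in the source may bear on it.

Measured in an assay on BTI cells for inhibition of Amine oxidase [flavin-containing] B (Homo sapiens), read by fluorescence and Amplex Red, with a stated time of 15 min; on this read-out lower numbers stand for stronger inhibition and higher numbers for weaker inhibition:
compound 1 `C#CCN(C)CCCCCCOc1ccc2c(c1)OCC2=O`: 51.9 nM
compound 2 `C#CCN(C)CCCCOc1ccc(C(C)=O)cc1`: 56.5 nM
compound 3 `C#CCN(C)CCCCCOc1cccc(OC)c1`: 101 nM

Compound 3 carries the highest number of the three, yet its gaps to compound 2 and to compound 1 both fall within the scatter, so the three read as one level. Compound 4 `C#CCN(C)CCCCCOc1ccc(C=O)c(OC)c1` differs from compound 3 by formyl in place of hydrogen on an aromatic carbon. For the measured compounds named here, no measured pair shows this change. Compound 2 and compound 1 each carry a carbonyl on the aromatic part and sit within the scatter of compound 3, so the expected step of a 1.7-fold lower number from compound 3 to compound 4 (0.23 log units; within the scatter) in this assay is small, if anything toward a lower number. Compound 4 is expected to give 60 nM, with a range from 20 nM to 180 nM.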

Compound 4, half-maximal inhibitory concentration: 5740 nM
The estimate for compound 4 lay 96-fold (1.98 log units) below the measured number, outside the stated range (above it).
By their numbers in this assay, from the lowest: compounds 1, 2 and 3 (each within the scatter of the next); then compound 4.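

In this assay, formyl in place of hydrogen, on the aromatic carbon ortho to a methoxy group and para to a large group, gives a 57-fold higher number from compound 3 to compound 4 (1.75 log units; beyond the scatter) and so is a large loss. For the compounds shown here, this is the first step that clearly exceeds the scatter: this position responds strongly to an entering group of only 2 heavy atoms. No measurement available here accounts for the step.
As far as these compounds go, whether any group on this carbon costs as much remains open; a fluorine atom, an amine or a carboxylic acid there would test this. From the compounds shown here alone, whether the loss persists with a longer chain also remains open.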